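Swapping the aminophenyl for a difluorophenyl on a chalcone

A few compounds are considered here, and "the series" means these few. Any claim that something is new, unique, unknown or untested is made for them only; others in the source may bear on it.

Measured compounds:
- compound 1 `COc1cc(-c2cc(/C=C/C(=O)c3ccc(N)cc3)[nH]n2)cc(OC)c1OC`: 91%
- compound 2 `COc1ccc(-c2cc(/C=C/C(=O)c3ccc(N)cc3)[nH]n2)cc1`: 98%
- compound 3 `COc1cc(C(=O)/C=C/c2cc(-c3cc(OC)c(OC)c(OC)c3)n[nH]2)cc(OC)c1OC`: 94%

Of the compounds shown here, three sharing a pyrazole-linked chalcone-type core have been tested in a functional assay on CCRF-CEM cells (Homo sapiens) for cytotoxicity, read by sulforhodamine B assay, with a stated time of 48 h, tested at 0.1 uM; on this read-out higher numbers stand for a weaker effect at the one concentration tested and lower numbers for a stronger effect. Compound 1 gives the smallest of the three numbers, but its gaps to compound 3 and to compound 2 both lie within the usual scatter of this assay, so the three cannot be told apart: all of them leave most of the cells unaffected at the single concentration used.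

Compound 4 `COc1cc(-c2cc(/C=C/C(=O)c3ccc(F)c(F)c3)[nH]n2)cc(OC)c1OC` has not yet been measured. It differs from compound 1 in one place: 3,4-difluorophenyl in place of 4-aminophenyl on a carbonyl carbon. The nitrogen-bearing group that could donate and accept hydrogen bonds is gone, and two fluorine atoms sit on the ring instead.

Going by the values given here, no step between measured compounds is available to calibrate this change. Since compound 1, compound 2 and compound 3 all sit in the same weak region of this assay, the step expected a number 1 percentage points higher from compound 1 to compound 4 (within the scatter) is small, no larger than the scatter, in either direction. Compound 4 is therefore estimated to give 92%, within 75% to 104%.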

Compound 4, a percentage reported as activity, at one concentration (the size of the read-out at that concentration, not a potency): 96%
Estimate against measurement, compound 4: 4 percentage points below; low and high end bracket the measured number.
By their numbers in this assay, from the lowest: compounds 1, 3, 4 and 2 (each within the scatter of the next).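

In this assay, 3,4-difluorophenyl in place of 4-aminophenyl on a carbonyl carbon gives a number 5 percentage points higher from compound 1 to compound 4 (within the scatter). Going by these compounds alone, this is the first comparison in the set that changes a single place, and at this one concentration the read-out does not separate the two groups, even though the hydrogen-bond donor and acceptor counted on 4-aminophenyl are absent from 3,4-difluorophenyl. No measurement shown here bears on why compound 1 and compound 4 read alike.

Going by these compounds, both compounds leave most of the cells unaffected at this concentration, so it remains open whether the two groups would differ at a concentration where the cells respond more strongly. Also open, on these data alone, is how a phenyl carrying a carboxylic acid, or one carrying a dimethylamino group, would read on the same carbonyl carbon.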